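Hydroxy in Place of a Triazole at the Chain End

This account rests on a few compounds, and the source may have more. Where it says the series, first, only, none or still open, it means among the compounds named here.

Three compounds have numbers in a functional assay on HCT-116 cells (Homo sapiens) for antiproliferative activity, read by sulforhodamine B assay, with a stated time of 72 h; on this read-out higher numbers stand for weaker inhibition and lower numbers for stronger inhibition. Compound 1 `Cn1ncc(Cl)c1-c1cc(C(=O)N[C@@H]2CNCC[C@H]2c2ccc(C(F)(F)F)cc2)oc1Cl` gives 280 nM, compound 2 `Cn1ncc(Cl)c1-c1cc(C(=O)N[C@@H]2CN[C@H](CCn3cncn3)C[C@H]2c2ccc(Cl)c(Cl)c2)oc1Cl` gives 560 nM, and compound 3 `O=C(N[C@@H]1CNCC[C@H]1c1ccc(Cl)cc1)c1ccc(-c2ncnc3c2CCC3O)s1` gives 23000 nM. Compound 2 therefore stands second highest of the three; its nearest neighbour is compound 1, within the usual scatter, while compound 3 lies far beyond it. The account now turns to compound 4 `Cn1ncc(Cl)c1-c1cc(C(=O)N[C@@H]2CN[C@H](CCO)C[C@H]2c2ccc(Cl)c(Cl)c2)oc1Cl`, which differs from compound 2 in a single place: hydroxy in place of 1H-1,2,4-triazol-1-yl on a saturated chain carbon, two bonds along the chain from a saturated ring carbon. Going by the values given here, no measured pair shows this same change, so its size is open. In this assay the step of a 1.4-fold higher number from compound 2 to compound 4 (0.15 log units; within the scatter) is expected to stay within the scatter or lean slightly toward weaker inhibition. Compound 4 is thus estimated at 800 nM, within a range from 300 nM to 2200 nM.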

Compound 4, half-maximal inhibitory concentration: 340 nM
Beside the measured number, compound 4's estimate is 2.4-fold (0.37 log units) above it; the range from low to high includes it.
By their numbers in this assay, from the lowest: compounds 1, 4 and 2 (each within the scatter of the next); then compound 3.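

In this assay, the ring-bearing 1H-1,2,4-triazol-1-yl on this saturated chain carbon can be exchanged for a single hydroxy with no step beyond the scatter, as shown by a 1.6-fold lower number from compound 2 to compound 4 (0.22 log units; within the scatter). The number at this place therefore does not depend on keeping the triazole ring, at least for this one pair. Nothing shown explains this outcome. On these data alone, whether an amine, a carboxylic acid or a longer chain ending in hydroxy would also stay within the scatter here remains open. So does whether the same exchange would behave alike on another core.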